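The source may hold more compounds than are shown below. What is called first, only, known or untested is meant among the compounds shown, and "the series" means these compounds.

Measured compounds:
compound 1 `CC1CCN(C2CCN(S(=O)(=O)c3cccc(C(F)(F)F)c3)CC2)CC1`, giving > 5000 nM in a functional assay on DLD-1 cells (Homo sapiens) for antiproliferative activity, read by CellTiter-Glo, with a stated time of 72 h; on this read-out lower numbers stand for stronger inhibition and higher numbers for weaker inhibition
compound 2 `Cc1cc(C)c(S(=O)(=O)N2CCN(C3CN4CCC3CC4)CC2)c(C)c1`, giving 84 nM in this assay
compound 3 `Cc1cc(C)c(S(=O)(=O)N2CCC(N3CCC(c4ccccc4)CC3)CC2)c(C)c1`, giving 865 nM in this assay

Compound 1 stands apart from the other two on these numbers. Its value of > 5000 nM in this assay is a limit of the assay and not a number, so only an upper bound on its potency is known. Among the three values shown, compound 1 is the one sitting at the limit of > 5000 nM in this assay, at which 1 of the 3 values shown sits. Compound 2 and compound 3, by contrast, give measured numbers in this assay, and their two values lie well apart.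

Compound 4 `CC1CCN(C2CCN(S(=O)(=O)c3cccc(N)c3)CC2)CC1` differs from compound 1 in one place: amino in place of trifluoromethyl on an aromatic carbon. Among the compounds with values here, no pair of measured compounds that differ in one place is available here, so no measured step guides the direction of this change. With compound 1 known only as a limit, the step is expected to be small and of uncertain direction, and compound 4 is estimated at 6000 nM, within a range of 1500 nM to 25000 nM. The expected step from compound 1 to compound 4 is a step that the limit leaves unreadable from compound 1 to compound 4, with a high chance that compound 4 again returns only a limit.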

Compound 4, half-maximal inhibitory concentration: 3400 nM
Beside the measured number, compound 4's estimate is 1.8-fold (0.25 log units) above it; the measured number falls inside the stated range.
By their numbers in this assay, from the lowest: compound 2; then compound 3; then compound 4. At a limit, above all of these: compound 1.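

In this assay compound 4, with amino on an aromatic carbon meta to a large group, gives 3400 nM, so this position with amino yields a measured number where trifluoromethyl gave none. The change amounts to an at least 1.4-fold lower number from compound 1 to compound 4 (0.16 log units; that floor lies within the scatter), which sets only a floor on the step and does not establish a real gain. The true size of the step cannot be read, because compound 1 gives a limit of the assay and not a number: the limit of > 5000 nM in this assay, at which 1 of the 4 values shown sits.

On these data alone, whether other groups at this position, such as a carboxylic acid, a nitrile or a methoxy group, would take the number further down remains open. Also open, as far as these compounds go, is whether amino would have any comparable effect on the cores of compound 2 and compound 3.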